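Swapping Nitro for Fluoro on a Shared Core

A few compounds are considered here, and "the series" means these few. Any claim that something is new, unique, unknown or untested is made for them only; others in the source may bear on it.

Measured so far:
compound 1 `CNC(=O)c1cc(Oc2ccc(C(=O)/C=C/c3ccc(Cl)c(Cl)c3)cc2)ccn1`: 11400 nM
compound 2 `CNC(=O)c1cc(Oc2ccc(C(=O)/C=C/c3ccc([N+](=O)[O-])cc3)cc2)ccn1`: "not determined" (no result reported)

In a functional assay on HepG2 cells (Homo sapiens) for cytotoxicity, read by MTT assay, with a stated time of 72 h (a lower number here means a stronger inhibitor, a higher number a weaker inhibitor), compound 1 gives 11400 nM. For compound 2 the result in this assay is "not determined" (no result reported), so compound 2 stands without a value on the numbers shown. Compound 3 `CNC(=O)c1cc(Oc2ccc(C(=O)/C=C/c3ccc(F)cc3)cc2)ccn1` differs from compound 2 in one place: fluoro in place of nitro on an aromatic carbon. Within the data shown here, with no measured step to lean on, the change is expected to move this assay only a little, in either direction, not beyond the scatter. Compound 3 is expected to give about 15000 nM in this assay, within a range from 4000 nM to 60000 nM.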

Compound 3, half-maximal inhibitory concentration: 12600 nM
Compound 3: the middle estimate sits 1.2-fold (0.08 log units) above what was measured, and the stated range covers the measured number.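

In this assay, 4-fluorophenyl in place of 3,4-dichlorophenyl gives a 1.1-fold higher number from compound 1 to compound 3 (0.04 log units; within the scatter), so these two groups cannot be told apart at this position. The nitro-to-fluoro step itself cannot be read: compound 2 has no value. Nothing measured here explains why the two groups read alike.

Two values cannot show how far this position can be changed before the number moves. Going by these compounds, whether an amine or a carboxylic acid on this phenyl ring would give a step beyond the scatter remains open.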